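Phenyl for Cyclopropyl on the Amide Nitrogen

The source may hold more compounds than are shown below. What is called first, only, known or untested is meant among the compounds shown, and "the series" means these compounds.

Compound 1 `COc1ncc(-c2ccc3c(c2)N(c2ccc(C)cc2)C(=O)CO3)cc1NS(=O)(=O)c1ccc(F)cc1`: 12900 nM
Compound 2 `O=C1COc2ccc(-c3cccc(NS(=O)(=O)c4ccc(F)cc4)c3)cc2N1C1CC1`: > 40000 nM
Compound 3 `COc1ccc(N2C(=O)COc3ccc(-c4cnc5ccccc5c4)cc32)cc1`: > 40000 nM

Of the compounds shown here, three have been tested in a functional assay on A-375 cells (Homo sapiens) for antiproliferative activity, read by MTT assay, with a stated time of 72 h; a lower number here means a stronger inhibitor, a higher number a weaker inhibitor. Compound 1 gives a measured number, 12900 nM. Compound 2 reports only a limit of the assay, > 40000 nM. Compound 3 likewise sits at a limit, > 40000 nM. Compound 2 therefore stands at the limit of > 40000 nM in this assay, at which 2 of the 3 values shown sit, without a number of its own. Compound 4 `O=C1COc2ccc(-c3cccc(NS(=O)(=O)c4ccc(F)cc4)c3)cc2N1c1ccccc1` differs from compound 2 in one place: phenyl in place of cyclopropyl on an amide-type nitrogen in a ring. Within the data shown here, no measured pair differs in one place only, so no measured step shows how this exchange acts. Compound 1, which carries an aromatic ring on that amide-type nitrogen, gives a number rather than a limit, so a modest gain is expected, possibly still within the scatter. Compound 4 is expected near 25000 nM, between 8000 nM and 60000 nM. The estimated step is an at least 1.6-fold lower number from compound 2 to compound 4 (0.20 log units; that floor lies within the scatter).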

Compound 4, half-maximal inhibitory concentration: > 40000 nM
Compound 4: no number, only a limit; the forecaster's own chance of this, stated with the estimate: 45%; at least 1.6-fold (0.20 log units) between middle value and limit.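

Compound 2 and compound 4 both report only limits, so no step can be read between them for phenyl in place of cyclopropyl. The compounds shown leave open whether this exchange changes antiproliferative activity at all.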